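Chloro for fluoro on a growth-inhibition series

The compounds below may be only part of what the source reports. "The series", "measured", "known", "first", "only" and "open" are said of these compounds alone.

Measured compounds:
Compound 1, `Nc1ccccc1NC(=O)/C=C/c1ccc(CSc2ccc(Cl)cc2)cc1`: 17.3%
Compound 2, `Nc1ccccc1NC(=O)/C=C/c1ccc(CSc2ccc(F)cc2)cc1`: 10.4%
Compound 3, `Nc1ccccc1NC(=O)c1ccc(CSc2ccc(F)cc2)cc1`: 79.3%

All three were tested in a functional assay on HeLa cells (Homo sapiens) for inhibition, read by CCK-8 assay, with a stated time of 72 h, tested at 8 uM; on this read-out lower numbers stand for less inhibition of growth and higher numbers for more inhibition of growth at the one concentration tested. Compound 3 stands highest of the three; compound 1 and compound 2 give numbers far lower. How the core of compound 3 differs from that of compound 2 is not broken down here.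

One structural change appears in two pairs. Between compound 2 and compound 1 it is chloro in place of fluoro on an aromatic carbon, and it gives a number 6.9 percentage points higher from compound 2 to compound 1 (within the scatter). Compound 4, `Nc1ccccc1NC(=O)c1ccc(CSc2ccc(Cl)cc2)cc1`, carries the same change on the core of compound 3: chloro in place of fluoro on an aromatic carbon. Both changes sit at the same kind of place on the ring.

Because the measured pair shows a number 6.9 percentage points higher from compound 2 to compound 1 (within the scatter), the step from compound 3 to compound 4 is expected to be small as well, about a number 0.7 percentage points higher from compound 3 to compound 4 (within the scatter) in this assay. Compound 4 is therefore estimated at 80% in this assay, most likely between 65% and 92%. This rests on one measured pair only, so the expectation is loose.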

Compound 4, percent growth inhibition at one concentration: 51.4%
Beside the measured number, compound 4's estimate is 28.6 percentage points above it; measured number below the stated range.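

In this assay, chloro in place of fluoro on an aromatic carbon gives a number 27.9 percentage points lower from compound 3 to compound 4 (beyond the scatter), so on this core the change goes with less growth inhibition at the one concentration tested. The effect of the change does not carry over from one core to the other: the same change on two cores in this assay, a number 6.9 percentage points higher (within the scatter) from compound 2 to compound 1 and a number 27.9 percentage points lower (beyond the scatter) from compound 3 to compound 4, 34.8 percentage points apart, beyond the scatter of two such steps. Among these compounds, this shows that, for these two pairs, the step on the core of compound 2 was a poor guide to the step on the core of compound 3, but with only one pair per core it does not show why the two differ, or whether the same would hold for other changes at this place.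

The compounds shown leave open how a bromo or a methyl group at that place on the ring would behave on either core. They also leave open whether the gap between the two cores would look the same at other concentrations.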